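A few compounds are considered here, and "the series" means these few. Any claim that something is new, unique, unknown or untested is made for them only; others in the source may bear on it.

Of the compounds shown here, three have so far been tested in a functional assay on Huh-7 cells (Homo sapiens) for cytotoxicity, read by resazurin assay, with a stated time of 48 h; on this read-out lower numbers stand for stronger inhibition and higher numbers for weaker inhibition. Compound 1 `CCOc1ccc(NC(=O)c2c(N)n[nH]c2Nc2ccccc2)cc1` gives 4320 nM in this assay. Compound 3 `CCNc1[nH]nc(N)c1C(=O)Nc1ccc(OCC)cc1` differs from compound 1 in one place, the change being (ethyl in place of phenyl on a nitrogen on an aromatic ring), and in this assay compound 3 gives 27000 nM. Put together, that change produced a 6.3-fold higher number from compound 1 to compound 3 (0.80 log units; beyond the scatter), so the smaller group on the ring nitrogen went with a clear weakening of cytotoxicity.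

Compound 2 `CCOc1ccc(-n2nnc3n[nH]c(Nc4ccccc4)c3c2=O)cc1` is built on a different core; the difference between the two cores is not broken down here. In this assay compound 2 gives 9390 nM, which lies between the numbers of compound 1 and compound 3.

Compound 4 `CCNc1[nH]nc2nnn(-c3ccc(OCC)cc3)c(=O)c12` has not yet been measured. It stands to compound 2 as compound 3 stands to compound 1, the difference being (ethyl in place of phenyl on a nitrogen on an aromatic ring). The place of the change is the same in both pairs, so this is the same change carried onto the second core. Within the data shown here, only one measured instance of it exists, the pair of compound 1 and compound 3, so how far it carries over is uncertain. On that basis the step from compound 2 to compound 4 is expected to be a 4.8-fold higher number from compound 2 to compound 4 (0.68 log units; beyond the scatter). Compound 4 is therefore estimated at 45000 nM in this assay. The expected range for compound 4 runs from 15000 nM up to 150000 nM.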

Compound 4, half-maximal inhibitory concentration: 14400 nM
Estimate against measurement, compound 4: 3.1-fold (0.49 log units) above, and the stated range ends above it.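

On the core of compound 2, putting ethyl in place of phenyl on the ring nitrogen gave a 1.5-fold higher number from compound 2 to compound 4 (0.19 log units; within the scatter) in this assay, so on this core the two groups cannot be told apart by this read-out. Among these compounds, the same change had a clear effect on the core of compound 1 and no readable effect here, so its size did not carry over from one core to the other, and the gap between the two steps is larger than the scatter can explain: the same change on two cores in this assay, a 6.3-fold higher number (0.80 log units; beyond the scatter) from compound 1 to compound 3 and a 1.5-fold higher number (0.19 log units; within the scatter) from compound 2 to compound 4, 4.1-fold (0.61 log units) apart, beyond the scatter of two such steps This does not show why the cores respond differently, and with only one pair on each core it gives no general rule for how this change, or any other, will transfer.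

As far as these compounds go, what a longer chain such as butyl, or a benzyl group, would do on this nitrogen remains open for both cores, as does whether the difference between the cores would persist with those groups. Also open, from the compounds shown here alone, is whether replacing the ethoxy group carried by all four compounds with an amine or a carboxylic acid would give matching steps on the two cores.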